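Carbamoylpyridinyl for carboxypyridinyl on the shared core

The source may report more compounds than this note shows. Statements on the series, on what has been measured and on what is new or still open speak of the compounds shown alone.

The measured compounds in an assay (Rattus norvegicus) for inhibition of Fatty-acid amide hydrolase 1 (Homo sapiens); on this read-out higher numbers stand for weaker inhibition and lower numbers for stronger inhibition:
Compound 1 `COc1ccccc1-c1cnc(C(=O)CCCCCCc2ccccc2)o1` gives 400 nM.
Compound 2 `O=C(CCCCCCc1ccccc1)c1ncc(-c2ccc(F)cc2)o1` gives 62 nM.
Compound 3 `O=C(CCCCCCc1ccccc1)c1ncc(-c2ncccc2C(=O)O)o1` gives > 50 nM, which is a limit of this assay and not a number.

Going by the values given here, compound 3 is the one of the three for which this assay reports only a limit (the limit of > 50 nM in this assay, at which 1 of the 3 values shown sits), so the step that the limit leaves unreadable from compound 1 to compound 3 and the step that the limit leaves unreadable from compound 2 to compound 3 cannot be read, and a 6.5-fold lower number from compound 1 to compound 2 (0.81 log units; beyond the scatter) remains the only step with a readable size. Compound 4 `NC(=O)c1cccc(-c2cnc(C(=O)CCCCCCc3ccccc3)o2)n1` carries 6-carbamoylpyridin-2-yl in place of 3-carboxypyridin-2-yl on an aromatic carbon. Among the compounds with values here, no measured step exchanges a carboxypyridinyl for a carbamoylpyridinyl, so the expected step that the limit leaves unreadable from compound 3 to compound 4 rests only on the limit of compound 3 and carries no direction that the measurements support. Compound 4 is estimated at 200 nM, between 40 nM and 1500 nM.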

Compound 4, inhibition constant: 1 nM
For compound 4 the middle estimate is 200-fold (2.30 log units) above the measured one; measured number below the stated range.
By their numbers in this assay, from the lowest: compound 4; then compound 2; then compound 1.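

At the aromatic carbon next to the ring oxygen, 6-carbamoylpyridin-2-yl gives the lowest number of the set in this assay, with a 62-fold lower number from compound 2 to compound 4 (1.79 log units; beyond the scatter) and a 400-fold lower number from compound 1 to compound 4 (2.60 log units; beyond the scatter), so the position allows far stronger inhibition than the two phenyl groups showed. Exchanging 3-carboxypyridin-2-yl for this group, with the counts of heavy atoms, donors and acceptors unchanged, gives an at least 50-fold lower number from compound 3 to compound 4 (1.69 log units; beyond the scatter). The figure for compound 3 is a limit and not a number: the limit of > 50 nM in this assay, at which 1 of the 4 values shown sits.

The compounds shown leave open whether the carbamoyl group or its place on the pyridine ring matters. A 6-carboxypyridin-2-yl, a 3-carbamoylpyridin-2-yl or a 6-cyanopyridin-2-yl group would separate the two.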